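Replacing the Vinylsulfonyl on Compound 2 with a Urea

A few compounds are considered here, and "the series" means these few. Any claim that something is new, unique, unknown or untested is made for them only; others in the source may bear on it.

Compound 1, `C=CS(=O)(=O)N1CCN(c2ncnc3sc(-c4ccc(OC)cc4)cc23)CC1`, gives 29900 nM in a functional assay on MDA-MB-231 cells (Homo sapiens) for antiproliferative activity, read by MTT assay, with a stated time of 48 h; a lower number here means a stronger inhibitor, a higher number a weaker inhibitor.
Compound 2, `C=CS(=O)(=O)N1CCN(c2ncnc3sc(-c4ccc(N5CCN(C)CC5)cc4)cc23)CC1`, gives 7550 nM.
Compound 3, `C=CS(=O)(=O)N1CCN(c2nc(OC[C@H]3CCCN3C)nc3sc(-c4ccc(N5CCN(C)CC5)cc4)cc23)CC1`, gives 760 nM.

Three compounds share one core and were tested in this assay. Compound 2 stands second highest of the three numbers: compound 1 is its nearest neighbour, and compound 3 lies furthest from it. The two measured steps both concern the far end of the shared core: a 4.0-fold lower number from compound 1 to compound 2 (0.60 log units; beyond the scatter), and a 9.9-fold lower number from compound 2 to compound 3 (1.00 log units; beyond the scatter). Compound 4, `CN1CCN(c2ccc(-c3cc4c(N5CCN(C(=O)Nc6ccccc6F)CC5)ncnc4s3)cc2)CC1`, differs from compound 2 at a different place, ((2-fluorophenyl)carbamoyl in place of vinylsulfonyl on an amine nitrogen in a ring). For the measured compounds named here, neither measured step touches this ring nitrogen, so no measured step bears directly on the change, and the expectation below rests only on the size of the steps seen elsewhere on the same core, which were modest. Compound 4 is therefore expected to give about 4000 nM, within a wide range from 800 nM to 20000 nM. That estimate means an expected step of a 1.9-fold lower number from compound 2 to compound 4 (0.28 log units; within the scatter), small against the scale of the measured steps and uncertain in direction.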

Compound 4, half-maximal inhibitory concentration: 10300 nM
Estimate against measurement, compound 4: 2.6-fold (0.41 log units) below; measured number inside the range.
By their numbers in this assay, from the lowest: compound 3; then compounds 2 and 4 (each within the scatter of the next); then compound 1.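

On the ring nitrogen, the first place in this series where a change can be read, (2-fluorophenyl)carbamoyl in place of vinylsulfonyl gives a 1.4-fold higher number from compound 2 to compound 4 (0.13 log units; within the scatter) in this assay, so the two compounds cannot be told apart in this read-out. The swap is not a small one: vinylsulfonyl gives way to a group with more heavy atoms, bringing a six-membered aromatic ring of carbon only and a hydrogen-bond donor, yet the number stays within the scatter, so for this pair the vinylsulfonyl group is not needed to keep this level of antiproliferative activity. Nothing at hand explains why two such different groups read alike.

From the compounds shown here alone, it remains open whether a much smaller group on the same nitrogen, such as acetyl, or a bare hydrogen on that nitrogen, would read the same way. Going by these compounds, it is also open whether the gain seen with (1-methylpyrrolidin-2-yl)methoxy, a 9.9-fold lower number from compound 2 to compound 3 (1.00 log units; beyond the scatter), would carry over to a compound bearing (2-fluorophenyl)carbamoyl on the ring nitrogen.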